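This account rests on a few compounds, and the source may have more. Where it says the series, first, only, none or still open, it means among the compounds named here.

Measured in a functional assay on A549 cells (Homo sapiens) for antiproliferative activity, read by MTT assay; on this read-out lower numbers stand for stronger inhibition and higher numbers for weaker inhibition:
- compound 1 `Cn1c(=O)c(=O)n(C2CCCC2)c2nc(N/N=C/c3ccc(Cl)cc3)ncc21`: 6890 nM
- compound 2 `Cn1c(=O)c(=O)n(C2CCCC2)c2nc(N/N=C/c3ccc(F)c(Cl)c3)ncc21`: 9410 nM
- compound 3 `Cn1c(=O)c(=O)n(C2CCCC2)c2nc(N/N=C/c3ccco3)ncc21`: > 100000 nM (a limit, not a number)

From the compounds shown here alone, compound 3 stands at the limit of this assay, so its true position on the scale is unknown. Compound 4 `Cn1c(=O)c(=O)n(C2CCCC2)c2nc(N/N=C/c3cccs3)ncc21` differs from it in one place, on a carbon with a double bond to nitrogen: thiophen-2-yl in place of furan-2-yl on a carbon with a double bond to nitrogen.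

Going by the values given here, no measured step makes this exact exchange. The closest evidence comes from changes on the same carbon. Two large steps beyond the scatter lead to furan-2-yl: an at least 14-fold higher number from compound 1 to compound 3 (1.16 log units; beyond the scatter) and an at least 10-fold higher number from compound 2 to compound 3 (1.02 log units; beyond the scatter). By contrast, a 1.4-fold higher number from compound 1 to compound 2 (0.14 log units; within the scatter) stays within the scatter. These steps show that the group at this place can matter greatly, but neither involves thiophen-2-yl.

A modest move toward a lower number is therefore expected, and compound 4 may well remain at the limit. For compound 4 the estimated value is 45000 nM, with an expected range of 15000 nM to 100000 nM. The expected change is an at least 2.2-fold lower number from compound 3 to compound 4 (0.34 log units; beyond the scatter).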

Compound 4, half-maximal inhibitory concentration: > 100000 nM
Compound 4 ended at the assay's limit; the forecaster's own chance of this, stated with the estimate: 40%; middle value at least 2.2-fold (0.34 log units) from the limit.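

In this assay, the large step at this carbon is no longer tied to furan-2-yl alone: thiophen-2-yl in place of 4-chlorophenyl gives an at least 14-fold higher number from compound 1 to compound 4 (1.16 log units; beyond the scatter), and thiophen-2-yl in place of 3-chloro-4-fluorophenyl gives an at least 10-fold higher number from compound 2 to compound 4 (1.02 log units; beyond the scatter). Sulfur in place of oxygen in the five-membered aromatic ring therefore does not bring the compound back into the measurable range. The step between compound 3 and compound 4 cannot be read, as both stand at a limit and not at a number: the limit of > 100000 nM in this assay, at which 2 of the 4 values shown sit.

From the compounds shown here alone, how far apart compound 3 and compound 4 truly lie remains open. Going by these compounds, it is also open whether an unsubstituted phenyl, a pyridine ring or a methoxy-bearing phenyl at this carbon would stay close to compound 1 or fall to the limit.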